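Aryl ketone swap and cytotoxicity on Vero cells

The source may report more compounds than this note shows. Statements on the series, on what has been measured and on what is new or still open speak of the compounds shown alone.

Compound 1 `COC(=O)c1cc(-c2cccc(NC(=O)c3ccc(/C=C/C(=O)c4ccc(F)cc4F)cc3)c2)on1` — in an ADME assay on Vero cells (Chlorocebus sabaeus) for cytotoxicity, read by MTT assay, with a stated time of 72 h (on this read-out higher numbers stand for lower toxicity in this test and lower numbers for higher toxicity in this test), compound 1 gives > 40 ug/mL, a limit of the assay.
Compound 2 `COC(=O)c1cc(-c2cccc(NC(=O)c3ccc(/C=C/C(=O)c4ccc(OC)c(OC)c4)cc3)c2)on1` — in this assay compound 2 gives > 50 ug/mL, also a limit.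

Compound 2 therefore stands only at a limit, not at a number. The step that the two limits leave unreadable from compound 1 to compound 2 cannot be sized because the limit of > 40 ug/mL in this assay, at which 1 of the 2 values shown sits, and the limit of > 50 ug/mL in this assay, at which 1 of the 2 values shown sits, are where the two values sit. Compound 3 `COC(=O)c1cc(-c2cccc(NC(=O)c3ccc(/C=C/C(=O)c4cccc([N+](=O)[O-])c4)cc3)c2)on1` carries 3-nitrophenyl in place of 3,4-dimethoxyphenyl on a carbonyl carbon. No readable measured step bears on this change, so compound 3 is expected to show no step beyond the scatter, with a number no higher from compound 2 to compound 3 (the limit leaves the size open) as the expected step. Compound 3 is estimated at 50 ug/mL, within 20 ug/mL to 120 ug/mL.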

Compound 3, half-maximal cytotoxic concentration: > 40 ug/mL
Compound 3: no number, only a limit; the forecaster's own chance of this, stated with the estimate: 70%; the middle value does not contradict the limit.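

No step from compound 1 or compound 2 to compound 3 can be read, since all three values are limits of the assay: the limit of > 40 ug/mL in this assay, at which 2 of the 3 values shown sit.

The compounds shown leave open whether the groups on the carbonyl carbon differ at all in this assay.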